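A Methoxy Swap at the Limit of the Assay

The compounds below may be only part of what the source reports. "The series", "measured", "known", "first", "only" and "open" are said of these compounds alone.

In a functional assay on Jurkat cells (Homo sapiens) for cytotoxicity, with a stated time of 24 h (a higher number here means a weaker inhibitor, a lower number a stronger inhibitor), compound 1 `Nn1c(SCc2cccc([N+](=O)[O-])c2)nnc1-c1c[nH]c2ccccc12` gives > 100000 nM, which is a limit and not a number. Compound 2 `Nn1c(SCc2ccc(F)cc2)nnc1-c1c[nH]c2ccccc12` gives > 100000 nM, again a limit. Compound 3 `Nn1c(SCc2ccc(Br)cc2)nnc1-c1c[nH]c2ccccc12` gives > 100000 nM, and this too is only a limit. Among the measured compounds shown here, the series so far therefore comes down to one observation: the limit of > 100000 nM in this assay, at which 3 of the 3 values shown sit.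

Compound 4 `COc1cccc(CSc2nnc(-c3c[nH]c4ccccc34)n2N)c1` has the same core as compound 3, but carries 3-methoxyphenyl in place of 4-bromophenyl on a saturated chain carbon bound to a sulfur.

For the measured compounds named here, the one measured step available for comparison is a step that the two limits leave unreadable from compound 2 to compound 3. It also changes the aromatic group, but it offers no size to carry over to the new compound. No measured number therefore points towards a stronger or a weaker inhibitor. The expectation rests on compound 3, whose reading of > 100000 nM is a limit. The estimated change is a number no higher from compound 3 to compound 4 (the limit leaves the size open), so no step beyond the scatter is expected in this assay. For compound 4 the estimated value is 100000 nM, with an expected range from 50000 nM to 200000 nM.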

Compound 4, half-maximal inhibitory concentration: > 100000 nM
Compound 4 ended at the assay's limit; the forecaster's own chance of this, stated with the estimate: 85%; the middle value sits exactly at the limit.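

The steps to compound 4 from compound 1, compound 2 and compound 3 cannot be read, because each of these readings is a limit and not a number: the limit of > 100000 nM in this assay, at which 4 of the 4 values shown sit.

The compounds shown leave open how strongly any of them acts in this assay and whether any change on the aromatic group makes a difference there.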